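A hydroxy group on the chain of compound 2

This account rests on a few compounds, and the source may have more. Where it says the series, first, only, none or still open, it means among the compounds named here.

Of the compounds shown here, two have been measured in a functional assay on ileum (Cavia porcellus) for antagonist activity, with a stated time of 30 s; on this read-out lower numbers stand for stronger inhibition and higher numbers for weaker inhibition. Compound 1 `O=C(O)c1cc(=O)c2cc(OCCCOc3ccccc3)ccc2o1` gives 3.3 ug/mL, while compound 2 `CCCc1ccccc1OCCCOc1ccc2c(=O)cc(C(=O)O)oc2c1CCC` gives 0.18 ug/mL. That is the lower of the two numbers, and the gap lies beyond the usual scatter, so compound 2 stands as the stronger inhibitor. The two compounds differ in more than one place, so their gap says nothing about any single change.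

Compound 3 `CCCc1ccccc1OCC(O)COc1ccc2c(=O)cc(C(=O)O)oc2c1CCC` differs from compound 2 by hydroxy in place of hydrogen on a saturated chain carbon bound to two saturated chain carbons. Among the compounds with values here, no measured pair shows this change, so no step beyond the scatter is expected in this assay, in either direction. This expectation corresponds to an estimated 1.1-fold higher number from compound 2 to compound 3 (0.05 log units; within the scatter). For compound 3 the estimated value is 0.2 ug/mL, with an expected range of 0.06 ug/mL to 0.7 ug/mL.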

Compound 3, half-maximal inhibitory concentration: 0.044 ug/mL
For compound 3 the middle estimate is 4.5-fold (0.66 log units) above the measured one, and the stated range ends above it.
By their numbers in this assay, from the lowest: compound 3; then compound 2; then compound 1.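

In this assay, hydroxy in place of hydrogen on a saturated chain carbon bound to two saturated chain carbons gives a 4.1-fold lower number from compound 2 to compound 3 (0.61 log units; beyond the scatter), a step beyond the usual scatter and toward stronger inhibition. Within the data shown here, this is the first single change that can be read, since compound 1 and compound 2 differ in more than one place, and it shows that the inhibition responds to what sits on this chain carbon. Nothing available here bears on why the number falls with this change.

Going by these compounds, whether an amine or a methoxy group on this same carbon would shift the number in the same direction remains open. So does whether the hydroxy group would give a similar step on the chain of compound 1, which lacks the propyl groups of compound 2.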